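The source may report more compounds than this note shows. Statements on the series, on what has been measured and on what is new or still open speak of the compounds shown alone.

Compound 1 `O=c1ccc(-c2ccc3cn[nH]c3c2)cn1Cc1ccccc1C(F)(F)F`, compound 2 `O=C(N1CCOCC1)n1cc(-c2ccc3cn[nH]c3c2)ccc1=O` and compound 3 `NC(=O)c1ccc(Cn2cc(-c3ccc4cn[nH]c4c3)ccc2=O)cc1` share a core and differ only in what sits on the aromatic nitrogen of the six-membered ring. In an assay for inhibition of MAP kinase-interacting serine/threonine-protein kinase 2 (Homo sapiens), read by luminescence and ADP-Glo, with a stated time of 2 h (a lower number here means a stronger inhibitor, a higher number a weaker inhibitor), compound 1 gives 100 nM. Compound 2, by contrast, is reported in this assay only as a limit, > 2000 nM, not as a number. Compound 3 is likewise reported in this assay only as a limit, > 2000 nM. Where compound 2 stands can therefore be said only loosely: it sits at the upper limit, and (the limit of > 2000 nM in this assay, at which 2 of the 3 values shown sit), so no ranking among these two is possible and only compound 1 carries a measured figure.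

Compound 4 `Cn1cc(-c2ccc3cn[nH]c3c2)ccc1=O`, not yet measured, takes from compound 2 the change (methyl in place of (morpholin-4-yl)carbonyl on an aromatic nitrogen). For the measured compounds named here, no measured pair shows such a swap, so the size of the step in this assay is open. The expectation is a step of an at least 1.3-fold lower number from compound 2 to compound 4 (0.12 log units; that floor lies within the scatter), that is, a value near the limit, possibly within the measurable range. Compound 4 is thus estimated at 1500 nM, with a range from 300 nM to 5000 nM.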

Compound 4, half-maximal inhibitory concentration: > 2000 nM
Compound 4: no number, only a limit; the forecaster's own chance of this, stated with the estimate: 40%; middle value at least 1.3-fold (0.12 log units) away from the limit.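

Compound 4, like compound 2, is reported in this assay only as a limit, so no step can be read between the two: the limit of > 2000 nM in this assay, at which 3 of the 4 values shown sit.

The compounds shown leave open whether methyl in place of (morpholin-4-yl)carbonyl on an aromatic nitrogen changes inhibition at all.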